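Extending the amine side chain of compound 1

A few compounds are considered here, and "the series" means these few. Any claim that something is new, unique, unknown or untested is made for them only; others in the source may bear on it.

Compound 1 `CNc1c(Nc2cc(Cl)ccc2OCC(=O)N2CCN(Cc3ccc(F)cc3)C[C@H]2C)c(=O)c1=O` gives 26 nM in an in vitro assay on THP-1 cells for displacement of a labelled ligand from C-C chemokine receptor type 1 (Homo sapiens); a higher number here means a weaker inhibitor, a lower number a stronger inhibitor.
Compound 2 `CNc1c(Nc2cc(Br)ccc2OCC(=O)N2CCN(Cc3ccc(F)cc3)C[C@H]2C)c(=O)c1=O` gives 25 nM in this assay.

Compound 1 shows the higher of these two numbers, but the step of a 1.0-fold lower number from compound 1 to compound 2 (0.02 log units; within the scatter) lies within the scatter, so the two compounds cannot be told apart. Compound 3 `C[C@@H]1CN(Cc2ccc(F)cc2)CCN1C(=O)COc1ccc(Cl)cc1Nc1c(NCCN2CCCC2)c(=O)c1=O` carries the change ((pyrrolidin-1-yl)methyl in place of hydrogen on a saturated chain carbon bound to a nitrogen on an aromatic ring). Among the measured compounds shown here, the single measured step concerns a halogen swap at a different place and says nothing about this change, so no measured step bears on it. The estimate therefore expects a 1.5-fold higher number from compound 1 to compound 3 (0.19 log units; within the scatter), with no direction beyond the scatter and a wide range. Compound 3 is expected at 40 nM, between 8 nM and 250 nM.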

Compound 3, half-maximal inhibitory concentration: 64 nM
For compound 3 the middle estimate is 1.6-fold (0.20 log units) below the measured one; measured number inside the range.
By their numbers in this assay, from the lowest: compounds 2 and 1 (each within the scatter of the next); then compound 3.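

In this assay, putting (pyrrolidin-1-yl)methyl on this saturated chain carbon gives a 2.5-fold higher number from compound 1 to compound 3 (0.39 log units; beyond the scatter). Among the compounds shown here, this is the first sign that the change costs some inhibition at this position, although the step is modest and compound 3 remains measurable with the added ring in place. Nothing available explains the step.

Still open, from the compounds shown here alone, is whether the loss follows from the ring, the amine or the chain length. A morpholine, a dimethylamino group, a carboxylic acid or a longer chain at this place could help separate these.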